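The compounds below may be only part of what the source reports. "The series", "measured", "known", "first", "only" and "open" are said of these compounds alone.

Measured in a functional assay on HL-60 cells (Homo sapiens) for inhibition, read by CCK-8 assay, with a stated time of 48 h, tested at 20 uM; a lower number here means less inhibition of growth, a higher number more inhibition of growth at the concentration tested:

- Compound 1 `N#C/C(=C\c1ccccc1OS(=O)(=O)c1ccc(F)cc1)C(=O)Nc1nnc(Cc2cccc3ccccc23)s1`: 12%
- Compound 2 `N#C/C(=C\c1ccccc1OS(=O)(=O)c1ccc([N+](=O)[O-])cc1)C(=O)Nc1nnc(Cc2ccc(Cl)cc2)s1`: 34%

Compound 2 stands higher of the two at 34%, beyond the scatter from compound 1. Compound 3 `N#C/C(=C\c1ccccc1OS(=O)(=O)c1ccc(F)cc1)C(=O)Nc1nnc(Cc2ccc(Cl)cc2)s1` departs from compound 2 in one place: fluoro in place of nitro on an aromatic carbon. This is fluoro in place of nitro on an aromatic carbon, para to a large group. Among the measured compounds shown here, no pair of measured compounds differs in one place only, so this change has no direct measure. Compound 1 also carries the 4-fluorophenyl group and gives 12%, but it differs from compound 3 elsewhere as well and offers only a loose guide. A moderate fall in this assay is therefore expected, near the edge of the scatter. The expected change is a number 10 percentage points lower from compound 2 to compound 3 (within the scatter). For compound 3, the estimated value is 24%, within an expected range of 8% to 42%.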

Compound 3, percent growth inhibition at one concentration: 20%
The estimate for compound 3 lay 4 percentage points above the measured number; the measured number falls inside the stated range.
By their numbers in this assay, from the lowest: compounds 1 and 3 (each within the scatter of the next); then compound 2.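

In this assay, among the compounds shown here, the step from the (4-nitrophenyl)sulfonyl to the (4-fluorophenyl)sulfonyl group gives a first direct reading at this position, with a number 14 percentage points lower from compound 2 to compound 3 (beyond the scatter) as a modest difference on an otherwise identical structure. With the (4-fluorophenyl)sulfonyl group held, 4-chlorophenyl in place of naphthalen-1-yl gives a number 8 percentage points higher from compound 1 to compound 3 (within the scatter) and so does not separate these two groups in this read-out. Nothing measured alongside these numbers bears on the result.

This single pair cannot show whether the nitro step holds when naphthalen-1-yl stands in place of 4-chlorophenyl. Also open, as far as these compounds go, is where an amine, a carboxylic acid or a methoxy group on the same aromatic carbon would fall relative to compound 2 and compound 3.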